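This account rests on a few compounds, and the source may have more. Where it says the series, first, only, none or still open, it means among the compounds named here.

In a functional assay on CHO cells for positive allosteric modulation of muscarinic acetylcholine receptor M5 (Homo sapiens), read by FLIPR and calcium flux, with a stated time of 1 h (a lower number here means a smaller maximal response, a higher number a larger maximal response), compound 1 `O=C1C(=O)N(Cc2ccc(-c3cccnc3)cc2)c2ccc(OC(F)(F)F)cc21` gives 51%, compound 2 `O=C1C(=O)N(Cc2ccc(-c3cncnc3)cc2)c2ccc(OC(F)(F)F)cc21` gives 53% and compound 3 `O=C1C(=O)N(Cc2ccc(Oc3nccs3)cc2)c2ccc(OC(F)(F)F)cc21` gives 58%. Compound 3 shows the highest of the three numbers, yet the steps of a number 7 percentage points higher from compound 1 to compound 3 (within the scatter) and a number 5 percentage points higher from compound 2 to compound 3 (within the scatter) lie within the scatter, as does a number 2 percentage points higher from compound 1 to compound 2 (within the scatter). Compound 4 `O=C1C(=O)N(Cc2ccc(-c3ccncc3)cc2)c2ccc(OC(F)(F)F)cc21` changes the same place once more: pyridin-4-yl in place of (1,3-thiazol-2-yl)oxy on an aromatic carbon. Going by the values given here, the steps that bear on this, a number 7 percentage points higher from compound 1 to compound 3 (within the scatter) and a number 5 percentage points higher from compound 2 to compound 3 (within the scatter), exchange pyridin-3-yl or pyrimidin-5-yl for (1,3-thiazol-2-yl)oxy and are both small, so no step beyond the scatter is expected here either. Compound 4 is expected to stay close to its neighbours, the step of a number 8 percentage points lower from compound 3 to compound 4 (within the scatter) being estimated to remain within the scatter. The estimate for compound 4 is 50%, between 38% and 62%.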

Compound 4, largest response reached (Emax), in percent of the reference or control that the assay uses: 60%
Beside the measured number, compound 4's estimate is 10 percentage points below it, within the range that was stated.
By their numbers in this assay, from the lowest: compounds 1, 2, 3 and 4 (each within the scatter of the next).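

Pyridin-4-yl fits the same pattern at this place, with no step beyond the scatter: the change gives a number 2 percentage points higher from compound 3 to compound 4 (within the scatter), a number 7 percentage points higher from compound 2 to compound 4 (within the scatter) and a number 9 percentage points higher from compound 1 to compound 4 (within the scatter). The pyridin-3-yl and pyridin-4-yl groups therefore cannot be told apart here, and neither ring can be told from pyrimidin-5-yl or (1,3-thiazol-2-yl)oxy, so all four groups give maximal responses within the scatter of one another. Nothing shown explains these numbers. From the compounds shown here alone, whether an amine, a carboxylic acid or a morpholine ring at this place would keep the maximal response in the same range remains open.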